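Methyl to methoxy on the benzamide ring of compound 2

The source may report more compounds than this note shows. Statements on the series, on what has been measured and on what is new or still open speak of the compounds shown alone.

The series shares one core, an anilide carrying a sulfonanilide, and is followed in a functional assay on HEK293 cells for agonist activity at probable G-protein coupled receptor 27 (Homo sapiens), read by a luciferase reporter and beta-arrestin recruitment, with a stated time of 10 min; a lower number here means that less compound is needed, a higher number that more compound is needed for the effect. Compound 1 `O=C(Nc1ccc(S(=O)(=O)Nc2ccccc2)cc1)c1ccc(Cl)cc1F` gives 3980 nM. Within the data shown here, compound 2 `Cc1cc(Br)ccc1C(=O)Nc1ccc(S(=O)(=O)Nc2ccccc2)cc1` gives 851 nM, and the step of a 4.7-fold lower number from compound 1 to compound 2 (0.67 log units; beyond the scatter) is the only one-point change measured so far. Compound 3 `Cc1ccccc1NS(=O)(=O)c1ccc(NC(=O)c2ccc(Cl)cc2Cl)cc1` gives 1230 nM; compound 2 and compound 3 differ in two places, and their two numbers lie within the usual scatter of each other, so no order between them is claimed. Compound 2 therefore holds the lowest number of the three, separated beyond the scatter only from compound 1.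

Compound 4 `COc1cc(Br)ccc1C(=O)Nc1ccc(S(=O)(=O)Nc2ccccc2)cc1` is the next step from compound 2: methoxy in place of methyl on an aromatic carbon. The change sits ortho to a large group and meta to a bromo group, on an aromatic carbon of a six-membered aromatic ring of carbon only. Among the measured compounds shown here, no measured step touches this position alone: the step from compound 1 to compound 2 moved both halogen and the ortho substituent together, and compound 3 varies elsewhere as well. With nothing bearing directly on methyl against methoxy, no step beyond the scatter is expected in this assay, and the expected step of a 1.1-fold higher number from compound 2 to compound 4 (0.02 log units; within the scatter) is accordingly small. Compound 4 is estimated at 900 nM, with a range from 300 nM to 2700 nM.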

Compound 4, half-maximal effective concentration: 1020 nM
For compound 4 the middle estimate is 1.1-fold (0.05 log units) below the measured one; the measured number falls inside the stated range.
By their numbers in this assay, from the lowest: compounds 2, 4 and 3 (each within the scatter of the next); then compound 1.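

In this assay, among these compounds, this position is read on its own for the first time: methoxy in place of methyl, which adds one oxygen and one hydrogen-bond acceptor on an aromatic carbon ortho to a large group, gives a 1.2-fold higher number from compound 2 to compound 4 (0.08 log units; within the scatter) and so opens no measurable gap. The separation from the 4-chloro-2-fluorophenyl compound survives the exchange, with a 3.9-fold lower number from compound 1 to compound 4 (0.59 log units; beyond the scatter) standing alongside a 4.7-fold lower number from compound 1 to compound 2 (0.67 log units; beyond the scatter), so that 4-bromo-2-methylphenyl and 4-bromo-2-methoxyphenyl both lie beyond the scatter from compound 1. No measurement at hand bears on why methyl and methoxy read alike here.

Both steps from compound 1 change the halogen and the group at this position together, so the share of each in the separation remains unresolved. On these data alone, it also remains open whether the flat reading at this position extends to a hydroxyl, an ethoxy, a dimethylamino group or a carboxylic acid, and whether it would hold with the bromo group replaced.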